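A Ring Exchange on Compound 1

The source may hold more compounds than are shown below. What is called first, only, known or untested is meant among the compounds shown, and "the series" means these compounds.

In a physicochemical assay for solubility, read by HPLC, in phosphate buffer, measured as kinetic solubility, with a stated time of 1 h, at pH 7.4, tested at 250 uM (a higher number here means a more soluble compound, a lower number a less soluble compound), compound 1 `CC(=O)N1CCC(c2ccc3c(c2)oc(=O)n3C(=O)NCCCCc2ccccc2)CC1` reads < 1000 nM, and this is a limit of the assay, not a number. Compound 2 `CC(C)CNC(=O)n1c(=O)oc2c(C3CCN(C)CC3)cccc21` gives 230000 nM in this assay.

Compound 3 `CN1CCN(c2ccc3c(c2)oc(=O)n3C(=O)NCCCCc2ccccc2)C(=O)C1` keeps the core of compound 1 but carries 4-methyl-2-oxopiperazin-1-yl in place of 1-acetylpiperidin-4-yl on an aromatic carbon. Among the compounds with values here, no measured pair of compounds isolates this exchange, so any expectation remains loose. A modest rise in this assay is expected, although the reading may again be only a limit. The estimated change is an at least 4.0-fold higher number from compound 1 to compound 3 (0.60 log units; beyond the scatter). The expected value for compound 3 is 4000 nM, with an estimated range from 1000 nM to 25000 nM.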

Compound 3, solubility: 20000 nM
Compound 3: the middle estimate sits 5.0-fold (0.70 log units) below what was measured; measured number inside the range.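

Within the data shown here, with the rest of compound 1 held constant, the exchange of 1-acetylpiperidin-4-yl for 4-methyl-2-oxopiperazin-1-yl on this aromatic carbon gives in this assay an at least 20-fold higher number from compound 1 to compound 3 (1.30 log units; beyond the scatter), the first step that can be read. The groups differ only modestly by count, with 8 heavy atoms in place of 9, 2 ring hetero atoms in place of 1 and 2 hydrogen-bond acceptors in place of 1, so a small change at this one place is enough for a large step. That step is a lower bound only, because the reading for compound 1 is a limit of the assay and not a number: the limit of < 1000 nM in this assay, at which 1 of the 3 values shown sits.

The compounds shown do not separate the part played by the second ring nitrogen from that of the ring carbonyl. From the compounds shown here alone, how a free secondary amine or a carboxylic acid on this carbon would read in this assay also remains open.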